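Compound 3 in the antiproliferative series: nitro for bromo

This account rests on a few compounds, and the source may have more. Where it says the series, first, only, none or still open, it means among the compounds named here.

Measured in a functional assay on U-251 cells (Homo sapiens) for antiproliferative activity, read by MTT assay, with a stated time of 24 h; a lower number here means a stronger inhibitor, a higher number a weaker inhibitor:
Compound 1 `C#CCOc1ccc2c(=O)c(-c3cc(OC)c(OC)cc3OC)coc2c1`: 6450 nM
Compound 2 `COc1cc(OC)c(-c2coc3cc(OCc4ccc(Br)cc4)ccc3c2=O)cc1OC`: 10000 nM

Compound 2 stands level with compound 1 within the scatter, so these two values give no ranking. Compound 3 `COc1cc(OC)c(-c2coc3cc(OCc4ccc([N+](=O)[O-])cc4)ccc3c2=O)cc1OC` differs from compound 2 by one exchange, nitro in place of bromo on an aromatic carbon, para to a large group: nitro in place of bromo on an aromatic carbon. Within the data shown here, no measured step makes this exchange. Among the measured compounds shown here, the only evidence nearby is a 1.6-fold higher number from compound 1 to compound 2 (0.19 log units; within the scatter), in which 4-bromophenyl replaced ethynyl on the saturated chain carbon, and that step stayed within the scatter. It is thin support, but it gives no reason to expect a large shift in this assay. An estimated step of a 1.3-fold lower number from compound 2 to compound 3 (0.10 log units; within the scatter) is expected, with no clear direction beyond the scatter. Compound 3 is expected at 8000 nM, with an estimated range from 3000 nM to 20000 nM.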

Compound 3, half-maximal inhibitory concentration: 9400 nM
For compound 3 the middle estimate is 1.2-fold (0.07 log units) below the measured one; the range from low to high includes it.
By their numbers in this assay, from the lowest: compounds 1, 3 and 2 (each within the scatter of the next).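

In this assay, the exchange of bromo for nitro on the aromatic carbon para to a large group gives a 1.1-fold lower number from compound 2 to compound 3 (0.03 log units; within the scatter), so this first change on the outer ring itself leaves the number level within the scatter, even with nitro bringing more heavy atoms and hydrogen-bond acceptors than bromo. Replacing ethynyl with 4-nitrophenyl gives a 1.5-fold higher number from compound 1 to compound 3 (0.16 log units; within the scatter), so a second 4-substituted phenyl group, like 4-bromophenyl before it, stays level with the ethynyl compound. No measurement shown here explains this lack of separation.

Going by these compounds, with all three compounds level within the scatter, it remains open whether any exchange here can move the number beyond it. An amine or a carboxylic acid on that same aromatic carbon, or a longer chain joining the outer ring to the oxygen, would test this.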